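Amide nitrogen substituent: step from compound 3 to compound 4

The compounds below may be only part of what the source reports. "The series", "measured", "known", "first", "only" and "open" are said of these compounds alone.

Measured so far:
compound 1, `Cc1cc(C(=O)O)nn1Cc1cc(Br)ccc1OCc1ccccc1`: 6.31 nM
compound 2, `CNC(=O)c1cc(C)n(Cc2cc(Cl)ccc2OCc2ccccc2)n1`: 100 nM
compound 3, `Cc1cc(C(=O)Nc2c(F)cccc2F)nn1Cc1cc(Cl)ccc1OCc1ccccc1`: 10 nM

In an assay on CHO-K1 cells for displacement of a labelled ligand from prostaglandin E2 receptor EP1 subtype (Homo sapiens) (on this read-out lower numbers stand for stronger inhibition and higher numbers for weaker inhibition), compound 1 gives 6.31 nM, compound 2 gives 100 nM and compound 3 gives 10 nM. Compound 3 and compound 1 lie within the scatter of one another, so no order between them is claimed. Within the data shown here, compound 2 stands apart: the one single-point step available, a 10-fold lower number from compound 2 to compound 3 (1.00 log units; beyond the scatter), is beyond the scatter and shows that the substituent on the amide nitrogen moves the number over a modest range within these three compounds.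

Compound 4, `Cc1cc(C(=O)NCc2cccnc2)nn1Cc1cc(Cl)ccc1OCc1ccccc1`, is not yet measured. It differs from compound 3 as follows: (pyridin-3-yl)methyl in place of 2,6-difluorophenyl on an amide-type nitrogen. Among the measured compounds shown here, the only measured step that bears on this place is the one from compound 2 to compound 3, where a small alkyl group on the amide nitrogen gave the higher number and the difluorinated aryl group the lower one. The entering group is neither of those, so the expectation is taken between the two ends of that step, nearer to compound 3. A moderately higher number than compound 3 is expected, estimated as a 4.0-fold higher number from compound 3 to compound 4 (0.60 log units; beyond the scatter). Compound 4 is thus estimated at 40 nM, with a range from 10 nM to 160 nM.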

Compound 4, half-maximal inhibitory concentration: 50.1 nM
Compound 4: the middle estimate sits 1.3-fold (0.10 log units) below what was measured; the range from low to high includes it.
By their numbers in this assay, from the lowest: compounds 1 and 3 (each within the scatter of the next); then compounds 4 and 2 (each within the scatter of the next).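

In this assay, (pyridin-3-yl)methyl in place of 2,6-difluorophenyl on the amide-type nitrogen gives a 5.0-fold higher number from compound 3 to compound 4 (0.70 log units; beyond the scatter), so a six-membered aromatic ring at this place does not by itself carry the number of compound 3. Adding pyridin-3-yl to the saturated chain carbon bound to the amide-type nitrogen gives a 2.0-fold lower number from compound 2 to compound 4 (0.30 log units; within the scatter), which resolves no change and leaves compound 3 as the only one of these three amides separated from the other two. Nothing measured here accounts for either step.

The compounds shown leave open whether the separation of compound 3 follows the fluorine atoms, the ring type or the saturated chain carbon, since (pyridin-3-yl)methyl differs from 2,6-difluorophenyl in all three at once. Plain phenyl, pyridin-3-yl and (2,6-difluorophenyl)methyl on the same amide-type nitrogen would separate these features, and a longer chain such as 2-(pyridin-3-yl)ethyl would show whether the number responds further to chain length.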